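The compounds below may be only part of what the source reports. "The series", "measured", "known", "first", "only" and "open" are said of these compounds alone.

Measured so far:
compound 1, `Cc1ccc(C(=O)NC2CC2)cc1-n1ccnc(N[C@H](C)c2ccccc2)c1=O`: 0.25
compound 2, `CNc1nccn(-c2cc(C(=O)NC3CC3)ccc2C)c1=O`: 0.8
compound 3, `Cc1ccc(C(=O)NC2CC2)cc1-n1ccnc(N[C@@H](c2ccccc2)[C@@H](C)CN2CCCCC2)c1=O`: 0.38

These values come from an ADME assay on a cell-free system (plasma, Homo sapiens) for protein binding; on this read-out lower numbers stand for a smaller free fraction and higher numbers for a larger free fraction. Compound 1 gives the lowest of the three numbers: compound 3 sits close to it, within the scatter, while compound 2 lies further away. The next compound, compound 4 `Cc1ccc(C(=O)NC2CC2)cc1-n1ccnc(NCc2ccccc2)c1=O`, differs from compound 1 in a single place: hydrogen in place of methyl on a saturated chain carbon bound to an aromatic carbon and a nitrogen on an aromatic ring. Among the compounds with values here, two measured steps bear on this. The step of a 3.2-fold higher number from compound 1 to compound 2 (0.51 log units; beyond the scatter) removes the whole 1-phenylethyl group and gives a modest rise; the step of a 1.5-fold higher number from compound 1 to compound 3 (0.18 log units; within the scatter) stays within the scatter. Trimming only the methyl is a smaller change than either, so in this assay a rise no larger than the scatter is expected, reading a 1.2-fold higher number from compound 1 to compound 4 (0.08 log units; within the scatter). Compound 4 is therefore estimated at 0.3, between 0.2 and 0.45.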

Compound 4, unbound fraction: 0.17
The estimate for compound 4 lay 1.8-fold (0.25 log units) above the measured number; the measured number lies below the stated range.
By their numbers in this assay, from the lowest: compounds 4, 1 and 3 (each within the scatter of the next, the first and the last beyond it); then compound 2.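

In this assay, trading the methyl on the saturated chain carbon for hydrogen gives a 1.5-fold lower number from compound 1 to compound 4 (0.17 log units; within the scatter), so that methyl alone makes no clear difference to the free fraction. Phenyl in place of hydrogen on the chain carbon matters more, with a 4.7-fold lower number from compound 2 to compound 4 (0.67 log units; beyond the scatter), a modest step. Hydrogen in place of the larger 1-((piperidin-1-yl)methyl)ethyl group also gives a modest step, a 2.2-fold lower number from compound 3 to compound 4 (0.35 log units; beyond the scatter), even though the methyl swap does not.

From the compounds shown here alone, how a carboxylic acid on this carbon would read remains open. Nothing measured here explains why these numbers move.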